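Swapping the aryl group in a flat cytotoxicity series

The compounds below may be only part of what the source reports. "The series", "measured", "known", "first", "only" and "open" are said of these compounds alone.

Compound 1 `COc1cc2ncnc(Nc3ccc(F)c(Cl)c3)c2cc1NC(=O)N/N=C/c1cccc(Br)c1` gives 28100 nM
Compound 2 `COc1ccc(/C=N/NC(=O)Nc2cc3c(Nc4ccc(F)c(Cl)c4)ncnc3cc2OC)cc1` gives 28100 nM
Compound 3 `COc1cc2ncnc(Nc3ccc(F)c(Cl)c3)c2cc1NC(=O)N/N=C/c1cc(OC)c(OC)c(OC)c1` gives 32100 nM

These three values come from a functional assay on A549 cells (Homo sapiens) for cytotoxicity, read by MTT assay, with a stated time of 72 h (a higher number here means a weaker inhibitor, a lower number a stronger inhibitor), and differ only through the group on a carbon with a double bond to nitrogen. Compound 3 cannot be told apart from the other two, with a 1.1-fold higher number from compound 1 to compound 3 (0.06 log units; within the scatter) and a 1.1-fold higher number from compound 2 to compound 3 (0.06 log units; within the scatter) as its steps. The other measured swap at this place, no change at the digits printed from compound 1 to compound 2 (within the scatter) as its result, is just as small. The next compound, compound 4 `COc1cc2ncnc(Nc3ccc(F)c(Cl)c3)c2cc1NC(=O)N/N=C/c1ccc(O)cc1O`, has 2,4-dihydroxyphenyl in place of 3,4,5-trimethoxyphenyl on a carbon with a double bond to nitrogen. In detail, 2,4-dihydroxyphenyl in place of 3,4,5-trimethoxyphenyl on a carbon with a double bond to nitrogen is the change. For the measured compounds named here, no measured compound carries hydroxy groups, so this swap is untested and the range must stay wide. Even so, all three measured swaps were silent, so the expected result in this assay is a 1.5-fold lower number from compound 3 to compound 4 (0.16 log units; within the scatter) and thus no real shift. Compound 4 is estimated at 22000 nM with an expected range from 8000 nM to 45000 nM on this read-out.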

Compound 4, half-maximal inhibitory concentration: 31400 nM
The estimate for compound 4 lay 1.4-fold (0.15 log units) below the measured number; measured number inside the range.
By their numbers in this assay, from the lowest: compounds 1, 2, 4 and 3 (each within the scatter of the next).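

In this assay, hydroxy groups on the aryl ring, new to this series, leave the number where it was: the swap gives a 1.0-fold lower number from compound 3 to compound 4 (0.01 log units; within the scatter), and the same group compared with the other two gives a 1.1-fold higher number from compound 2 to compound 4 (0.05 log units; within the scatter) and a 1.1-fold higher number from compound 1 to compound 4 (0.05 log units; within the scatter). The flat picture at this carbon with a double bond to nitrogen therefore now extends to an aryl group with hydrogen-bond donors, which the 3,4,5-trimethoxyphenyl group lacks, so gaining them and losing heavy atoms leaves no visible mark on this read-out. Nothing available explains this insensitivity.

As far as these compounds go, all four groups here are substituted phenyl rings, so it remains open whether any group at this place can move the number. An aryl ring carrying an amine or a carboxylic acid, or a plain alkyl chain in place of the ring, would test that.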